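This account rests on a few compounds, and the source may have more. Where it says the series, first, only, none or still open, it means among the compounds named here.

Of the compounds shown here, three have so far been measured in an ADME assay on Huh-7 cells (Homo sapiens) for cytotoxicity, read by MTT assay, with a stated time of 72 h; a higher number here means that more compound is tolerated, a lower number that less compound is tolerated.

Compound 1 `COc1cc(O)c(C(=O)/C=C/c2ccc(OCc3cn(-c4ccccc4Cl)nn3)c(OC)c2)c(OC)c1` gives > 100 ug/mL, which is a limit of the assay rather than a number.
Compound 2 `COc1cc(OC)c2c(=O)cc(-c3ccc(OCc4cn(-c5ccc(F)c(Cl)c5)nn4)c(OC)c3)oc2c1` gives > 100 ug/mL, also a limit.
Compound 3 `COc1cc(OC)c2c(=O)cc(-c3ccc(OCc4cn(-c5ccccc5Cl)nn4)c(OC)c3)oc2c1` gives > 100 ug/mL, again a limit.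

Compound 3 and compound 2 share one core and differ in a single place: 3-chloro-4-fluorophenyl in place of 2-chlorophenyl on an aromatic nitrogen. In this assay this change gives a step that the two limits leave unreadable from compound 3 to compound 2, since both ends of the step sit at a limit and no number is available on either side. For the measured compounds named here, the only evidence about this change is therefore (the limit of > 100 ug/mL in this assay, at which 3 of the 3 values shown sit), which says that none of the measured compounds harmed the cells within the tested range.

Compound 4 `COc1cc(O)c(C(=O)/C=C/c2ccc(OCc3cn(-c4ccc(F)c(Cl)c4)nn3)c(OC)c2)c(OC)c1` has not yet been measured. Going by the values given here, it differs from compound 1 by 3-chloro-4-fluorophenyl in place of 2-chlorophenyl on an aromatic nitrogen, the same change as the one from compound 3 to compound 2, at the same place in the same words. Compound 1 and compound 4 carry a core that is not the core of compound 3 and compound 2; how the two cores differ is not broken down here.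

For compound 4 a step that the limit leaves unreadable from compound 1 to compound 4 is expected, resting on (the limit of > 100 ug/mL in this assay, at which 3 of the 3 values shown sit), where the same change left both compound 3 and compound 2 at the limit. Compound 4 is therefore estimated at 120 ug/mL in this assay, most likely reported again as a limit, with a range from 60 ug/mL to 250 ug/mL.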

Compound 4, half-maximal cytotoxic concentration: > 100 ug/mL
Compound 4: only a limit was reported (the forecaster's own chance of this, stated with the estimate: 85%); the middle value does not contradict the limit.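

In this assay compound 4 gives > 100 ug/mL as a limit of the assay and not a number. For the compounds shown here, compound 1 sits at the same limit, so no step between compound 1 and compound 4 can be read. The compounds shown leave open at what concentration any of them would begin to harm the cells, and whether 3-chloro-4-fluorophenyl and 2-chlorophenyl differ in this respect at all.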